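Aminoquinoline series: acid dissociation, fluoro for tert-butyl

The source may report more compounds than this note shows. Statements on the series, on what has been measured and on what is new or still open speak of the compounds shown alone.

Measured so far:
compound 1 `COc1ccc(-c2ccc3c(NCCCNCc4cccc(OC)c4O)ccnc3c2)cc1` — 9.47
compound 2 `CC(C)(C)c1ccc(Oc2ccc3c(NCCCNCc4ccco4)ccnc3c2)cc1` — 9.28

In a physicochemical assay for acid dissociation, compound 1 gives 9.47 and compound 2 gives 9.28; the two numbers lie within the scatter of each other, so no order between them can be stated.

Compound 3 `Fc1ccc(Oc2ccc3c(NCCCNCc4ccco4)ccnc3c2)cc1` differs from compound 2 in one place: fluoro in place of tert-butyl on an aromatic carbon. The change sits on the aryl ether ring, far from the amine that is expected to carry the proton. Going by the values given here, no step between measured compounds bears on this change. The step from compound 2 to compound 3 in this assay is expected to be a number 0.02 log units higher from compound 2 to compound 3 (within the scatter), that is, none beyond the scatter. Compound 3 is estimated at 9.3, between 9 and 9.6.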

Compound 3, acid dissociation constant: 9.28
The estimate for compound 3 lay 0.02 log units above the measured number, and the stated range covers the measured number.
By their numbers in this assay, from the lowest: compounds 2, 3 and 1 (each within the scatter of the next).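

In this assay, going by these compounds alone, the first single-place comparison, 4-(tert-butyl)phenyl to 4-fluorophenyl gives no change at the digits printed from compound 2 to compound 3 (within the scatter), so this position tolerates a large change in group size without a reading beyond the scatter. Within the data shown here, the comparison covers only this one pair of groups at this one position. No supporting measurement accounts for the flat result.

Open, from the compounds shown here alone, is whether a carboxylic acid or an amine in place of fluoro on the same carbon would leave the reading equally flat. Also open, going by these compounds, is whether a longer chain in the shared core would shift it.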